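The source may hold more compounds than are shown below. What is called first, only, known or untested is meant among the compounds shown, and "the series" means these compounds.

Measured so far in an ADME assay on Vero 76 cells (Chlorocebus sabaeus) for cytotoxicity, read by MTT assay, with a stated time of 96 h; on this read-out higher numbers stand for lower toxicity in this test and lower numbers for higher toxicity in this test:
- compound 1 `Cc1cccc(C2CC(c3ccc(Oc4ccccc4)cc3)=NN2c2ccc(S(N)(=O)=O)cc2)c1` gives 81000 nM
- compound 2 `NS(=O)(=O)c1ccc(N2N=C(c3ccc(Oc4ccccc4)cc3)CC2c2ccc(F)cc2)cc1` gives 25000 nM

Among the compounds with values here, compound 2 holds the lower of the two numbers in this assay; the only other compound, compound 1, sits a 3.2-fold lower number from compound 1 to compound 2 (0.51 log units; beyond the scatter) above it, a gap beyond the usual scatter.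

Compound 3 `NS(=O)(=O)c1ccc(N2N=C(c3ccc(Oc4ccccc4)cc3)CC2c2cccc(Cl)c2)cc1` has not yet been measured. Relative to compound 2 the change is 3-chlorophenyl in place of 4-fluorophenyl on a saturated ring carbon. Within the data shown here, the one step known at this position, a 3.2-fold lower number from compound 1 to compound 2 (0.51 log units; beyond the scatter), was a modest move downward when 4-fluorophenyl replaced 3-methylphenyl on the same saturated ring carbon. It bears on the present change only loosely: the group entering here, 3-chlorophenyl, is neither of the two groups compared in that step, so its direction is not directly read from it. Nothing in the two numbers available says that 3-chlorophenyl should fall outside the span they set.

The number for compound 3 in this assay is therefore expected to lie between the two measured values, most likely a small move upward from compound 2, a 1.6-fold higher number from compound 2 to compound 3 (0.20 log units; within the scatter), which may not exceed the scatter. The estimate for compound 3 is 40000 nM, with a range from 12000 nM to 130000 nM.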

Compound 3, half-maximal cytotoxic concentration: 88000 nM
Compound 3: middle estimate off by 2.2-fold (0.34 log units), on the low side; the range from low to high includes it.
By their numbers in this assay, from the lowest: compound 2; then compounds 1 and 3 (each within the scatter of the next).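

In this assay, 3-chlorophenyl in place of 4-fluorophenyl on the saturated ring carbon gives a 3.5-fold higher number from compound 2 to compound 3 (0.55 log units; beyond the scatter) and so shows that a halogen on this phenyl group does not by itself bring the low number seen for compound 2. Chloro in place of methyl on the aromatic carbon gives a 1.1-fold higher number from compound 1 to compound 3 (0.04 log units; within the scatter) and leaves 3-methylphenyl and 3-chlorophenyl indistinguishable in this test, so that among the three compounds only the 4-fluorophenyl compound stands apart. No measured evidence is available that would explain this difference between the groups.

The step from 4-fluorophenyl to 3-chlorophenyl changes both the halogen and its place on the phenyl group, so the compounds shown cannot say which of the two changes matters; 3-fluorophenyl and 4-chlorophenyl would separate them. Also open, going by these compounds, is whether a phenyl group carrying an amine or a carboxylic acid at this saturated ring carbon would stay within the span of these three compounds.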